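Shortening the amino acid side chain on the shared core

A few compounds are considered here, and "the series" means these few. Any claim that something is new, unique, unknown or untested is made for them only; others in the source may bear on it.

Compound 1, `COc1cc(NC(C)CCCN2C(=O)[C@@H](C)N(C(=O)CN)C2(C)C)c2ncccc2c1`: > 3 h
Compound 2, `COc1cc(NC(C)CCCN2C(=O)CN(C(=O)[C@H](N)CCSC)C2(C)C)c2ncccc2c1`: > 3 h

Of the compounds shown here, two have been measured in an ADME assay on a cell-free system (plasma, Homo sapiens) for metabolic stability, with Plasma (Rattus norvegicus) as the target, read by HPLC; on this read-out higher numbers stand for a longer-lived compound and lower numbers for a shorter-lived compound. Compound 1, `COc1cc(NC(C)CCCN2C(=O)[C@@H](C)N(C(=O)CN)C2(C)C)c2ncccc2c1`, gives > 3 h in this assay, which is a limit of the assay rather than a number. Compound 2, `COc1cc(NC(C)CCCN2C(=O)CN(C(=O)[C@H](N)CCSC)C2(C)C)c2ncccc2c1`, gives > 3 h in this assay, again a limit of the assay and not a number. Compound 2 thus stands at the limit of > 3 h in this assay, at which 2 of the 2 values shown sit, and with both values sitting at that limit the two compounds cannot be placed in any order relative to each other.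

Compound 3, `COc1cc(NC(C)CCCN2C(=O)CN(C(=O)[C@@H](C)N)C2(C)C)c2ncccc2c1`, has not yet been measured in this assay. It differs from compound 2 by hydrogen in place of (methylsulfanyl)methyl on a saturated chain carbon, two bonds along the chain from an amine nitrogen and a carbonyl carbon. Going by the values given here, no measured pair in this set differs in a single place, so no step size for this kind of change has been established. Given that compound 2 already sits at the limit in this assay, the expected step is a step that the limit leaves unreadable from compound 2 to compound 3, which is none beyond the scatter. Compound 3 is therefore estimated to give 4 h in this assay, with a range from 2 h to 8 h, and the result is most likely to be reported as a limit once more.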

Compound 3, half-life: > 3 h
Compound 3: only a limit was reported; the forecaster's own chance of this, stated with the estimate: 80%; the middle value does not contradict the limit.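

Compound 2 and compound 3 each give only a limit of the assay and not a number, so no step between them can be read in this assay: the limit of > 3 h in this assay, at which 3 of the 3 values shown sit.

The compounds shown leave open how long each one actually lasts in this assay, and whether hydrogen in place of (methylsulfanyl)methyl changes the half-life at all.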